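This account rests on a few compounds, and the source may have more. Where it says the series, first, only, none or still open, it means among the compounds named here.

Among the measured compounds shown here, compound 1, `CC/C(=C\c1cc(OC)c(OC)c(OC)c1)C(=O)N1CCC=C(Cl)C1=O`, is the weakest of the three measured members in a functional assay on MDA-MB-231 cells (Homo sapiens) for cytotoxicity, read by MTT assay, with a stated time of 72 h (a higher number here means a weaker inhibitor, a lower number a stronger inhibitor), where compound 1 gives 7270 nM. Compound 2, `COc1cc(/C=C/C(=O)N2CCC=C(Br)C2=O)cc(OC)c1OC`, gives 2730 nM in this assay, and compound 3, `CC/C(=C\c1cc(OC)c(OC)c(OC)c1)C(=O)N1CCC=C(Br)C1=O`, gives 2120 nM. For the measured compounds named here, the one measured step that changes a single place is a 3.4-fold lower number from compound 1 to compound 3 (0.54 log units; beyond the scatter); the values of compound 2 and compound 3 lie within the scatter of each other. Compound 4, `CCC/C(=C\c1cc(OC)c(OC)c(OC)c1)C(=O)N1CCC=C(Cl)C1=O`, differs from compound 1 by methyl in place of hydrogen on a saturated chain carbon, two bonds along the chain from a double-bonded chain carbon. Going by the values given here, no measured step touches the saturated chain: the only step recorded concerns the halogen on the core, and the two chain variants among the measured compounds also differ in the halogen, so nothing measured here speaks to lengthening the chain by one carbon. On that basis the account expects the step from compound 1 to compound 4 to be a 1.0-fold lower number from compound 1 to compound 4 (0.02 log units; within the scatter), that is, nothing beyond the scatter in this assay. Compound 4 is therefore estimated at 7000 nM in this assay, within a range from 3000 nM to 16000 nM.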

Compound 4, half-maximal inhibitory concentration: 8130 nM
For compound 4 the middle estimate is 1.2-fold (0.06 log units) below the measured one; the measured number falls inside the stated range.
By their numbers in this assay, from the lowest: compounds 3 and 2 (each within the scatter of the next); then compounds 1 and 4 (each within the scatter of the next).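

In this assay the step from ethyl to propyl on the saturated chain reads as a 1.1-fold higher number from compound 1 to compound 4 (0.05 log units; within the scatter) and so the position two bonds along the chain from a double-bonded chain carbon accepts one more methyl with no change the assay can resolve. Among the compounds shown here, this is the first measured step at the saturated chain, and it contrasts with the halogen step on the core, which is a 3.4-fold lower number from compound 1 to compound 3 (0.54 log units; beyond the scatter) and so, of the two single-place steps, only the halogen change moves the number beyond the scatter. Nothing available explains why the added methyl leaves the number unmoved.

As far as these compounds go, whether the same lengthening behaves alike with bromo on the core remains open. So does the outcome for a longer chain such as butyl, or for a chain ending in an amine or a carboxylic acid.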